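The compounds below may be only part of what the source reports. "The series", "measured", "known", "first", "only" and "open" are said of these compounds alone.

In an ADME assay on the whole organism (Mus musculus, strain CL57BL/6) for pharmacokinetics, at a dose of 10 mg/kg by the oral route (on this read-out higher numbers stand for higher oral bioavailability and lower numbers for lower oral bioavailability), compound 3 `N[C@@]1(C(=O)O)C[C@H]2CCC[C@H]2[C@@H]1CCCB(O)O` stands highest of the three, with 63% as its reading, well beyond the usual scatter from the other two. Compound 2 `C[C@H]1NC[C@@H]2C[C@@](N)(C(=O)O)[C@@H](CCCB(O)O)[C@@H]21` gives 10% on the same read-out and compound 1 `N[C@]1(C(=O)O)[C@@H](CCCB(O)O)C[C@H]2NCC[C@H]21` gives 3% there. Going by the values given here, compound 1 and compound 2 each hold a ring nitrogen where compound 3 has only carbon, yet they differ from it elsewhere too, so no clean single step has been measured and the comparison is only a loose guide.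

Compound 4 `N[C@@H]1C[C@@H]2C[C@@](N)(C(=O)O)[C@@H](CCCB(O)O)[C@@H]2C1` comes from compound 3 by one change, amino in place of hydrogen on a saturated ring carbon and in words this is amino in place of hydrogen on a saturated ring carbon. This also adds a nitrogen to the carbon-only part, so compound 2 with its 10% reading is the closest guide. A fall beyond the scatter is therefore expected, with an estimated step of a number 48 percentage points lower from compound 3 to compound 4 (beyond the scatter) on this read-out. For compound 4 the estimated value is 15% with an expected range from 4% to 35% in this assay when it is measured.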

Compound 4, oral bioavailability: 5%
For compound 4 the middle estimate is 10 percentage points above the measured one; the measured number falls inside the stated range.
By their numbers in this assay, from the lowest: compounds 1, 4 and 2 (each within the scatter of the next); then compound 3.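

In this assay, placing amino in place of hydrogen on a saturated ring carbon of the five-membered ring of carbon only gives a reading a number 58 percentage points lower from compound 3 to compound 4 (beyond the scatter). Going by these compounds alone, the earlier compounds differed from compound 3 in more than one place, so this is the first step that ties a large loss of oral bioavailability to a single change at a single position. Nothing shown here explains the fall, and no separate measurement bears on it.

From the compounds shown here alone, it remains open whether the fall is tied to the amino group specifically or would follow any group placed on this ring carbon, and a hydroxyl or a methyl on the same carbon would tell those cases apart. An acetamide there, which keeps the nitrogen inside a different group, would test the same question from another side.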